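Chloro on the shared core: compound 1 to compound 4

The compounds below may be only part of what the source reports. "The series", "measured", "known", "first", "only" and "open" are said of these compounds alone.

compound 1 `COC(=O)c1ccc2[nH]cc(C3(c4c[nH]c5ccc(C(=O)OC)cc45)C(=O)Nc4ccccc43)c2c1` gives 980 nM
compound 2 `O=C1Nc2ccc(Cl)cc2C1(c1c[nH]c2ccc(Br)cc12)c1c[nH]c2ccc(Br)cc12` gives 1040 nM
compound 3 `O=C1Nc2ccccc2C1(c1c[nH]c2ccc(Cl)cc12)c1c[nH]c2ccc(Cl)cc12` gives 1310 nM

In a functional assay on SK-N-SH cells (Homo sapiens) for cytotoxicity, read by MTT assay, with a stated time of 48 h (a lower number here means a stronger inhibitor, a higher number a weaker inhibitor), these three compounds lie within the scatter of one another, so compound 1 stands level with compound 2 and compound 3, and no order can be read among them. Compound 4 (`COC(=O)c1ccc2[nH]cc(C3(c4c[nH]c5ccc(C(=O)OC)cc45)C(=O)Nc4ccc(Cl)cc43)c2c1`) differs from compound 1 in one place, with chloro in place of hydrogen on an aromatic carbon. Among the compounds with values here, no measured pair isolates this change. Compound 2 also carries a chloro but differs elsewhere too, and compound 2 gives 1040 nM without leaving the scatter around compound 1. On that limited evidence, no step beyond the scatter is expected in this assay, and neither direction is favoured. The estimated change is a 1.0-fold lower number from compound 1 to compound 4 (0.01 log units; within the scatter). For compound 4 the expected value is 950 nM, with an estimated range from 480 nM to 1900 nM.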

Compound 4, half-maximal inhibitory concentration: 9900 nM
Compound 4: middle estimate off by 10-fold (1.02 log units), on the low side; measured number outside the range, above it.
By their numbers in this assay, from the lowest: compounds 1, 2 and 3 (each within the scatter of the next); then compound 4.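

In this assay, within the data shown here, chloro in place of hydrogen gives a 10-fold higher number from compound 1 to compound 4 (1.00 log units; beyond the scatter), the first step beyond the scatter and the only measured pair that isolates this change. This aromatic carbon, on the six-membered aromatic ring of carbon only, meta to a fused ring and para to a fused ring, is therefore not indifferent to substitution on the core of compound 1, and with these two groups the lower number belongs to hydrogen. No measured property available here accounts for the step.

Going by these compounds, whether the step belongs to chloro specifically or to any group at this carbon stays open, and a fluoro or methoxy group there would separate the two. Also open, on these data alone, is whether the same step appears when bromo replaces the methyl ester groups of compound 4.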